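Swapping an aryloxymethyl amide for an aryl urea

This account rests on a few compounds, and the source may have more. Where it says the series, first, only, none or still open, it means among the compounds named here.

Measured compounds:
- compound 1 `Nc1nc(N2CCN(C(=O)COc3ccc(Cl)cc3)CC2)c2cc(F)sc2n1`: 700 nM
- compound 2 `Nc1nc(N2CCN(C(=O)C3CCCCC3)CC2)c2cc(F)sc2n1`: > 10000 nM
- compound 3 `Nc1nc(N2CCN(C(=O)COc3ccc(Cl)cc3)CC2)c2ccsc2n1`: 330 nM

In a functional assay on cells (Lymphocyte) (a higher number here means a weaker inhibitor, a lower number a stronger inhibitor), compound 3 gives 330 nM, the lowest of the two numbers given; the nearest is compound 1, which sits a 2.1-fold lower number from compound 1 to compound 3 (0.33 log units; beyond the scatter) away along the change of hydrogen in place of fluoro on an aromatic carbon. Compound 2 reports only a limit, (the limit of > 10000 nM in this assay, at which 1 of the 3 values shown sits), and not a number.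

Compound 4 `Nc1nc(N2CCN(C(=O)Nc3ccc(Cl)cc3)CC2)c2ccsc2n1` differs from compound 3 at the carbonyl carbon: (4-chlorophenyl)amino in place of (4-chlorophenoxy)methyl on a carbonyl carbon. Among the compounds with values here, the only measured step at that carbon is an at least 14-fold higher number from compound 1 to compound 2 (1.15 log units; beyond the scatter), where cyclohexyl in place of (4-chlorophenoxy)methyl removed the aromatic ring entirely and the value ran to the limit. Within the data shown here, compound 4 keeps the chlorinated aromatic ring, so that loss is not expected to repeat, but the linker between the carbonyl and the ring is changed, and no measured pair speaks to that. The step is therefore expected to be modest, with its direction uncertain, leaning toward a somewhat higher number: a 1.8-fold higher number from compound 3 to compound 4 (0.26 log units; within the scatter). Compound 4 is expected to give about 600 nM in this assay, within a range from 150 nM to 3000 nM.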

Compound 4, half-maximal inhibitory concentration: 6700 nM
Beside the measured number, compound 4's estimate is 11-fold (1.05 log units) below it; the measured number lies above the stated range.
By their numbers in this assay, from the lowest: compound 3; then compound 1; then compound 4. At a limit, above all of these: compound 2.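

In this assay, the urea-type change at the carbonyl carbon is costly: a 20-fold higher number from compound 3 to compound 4 (1.31 log units; beyond the scatter), with (4-chlorophenyl)amino in place of (4-chlorophenoxy)methyl. Within the data shown here, the only earlier step at this carbon, an at least 14-fold higher number from compound 1 to compound 2 (1.15 log units; beyond the scatter), took the aromatic ring away altogether, so it left open whether the ring alone was what counted; compound 4 keeps a six-membered aromatic ring carrying chlorine and still loses most of the inhibition seen with compound 3, which shows that the ring alone does not hold the value and that what joins it to the carbonyl carbon matters as well. The earlier step gives only a lower bound on its size, as compound 2 is a limit and not a number: the limit of > 10000 nM in this assay, at which 1 of the 4 values shown sits.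

The entering group differs from the leaving one both in its heavy atoms and in carrying a hydrogen-bond donor, and the compounds shown cannot separate these two changes. As far as these compounds go, a 2-(4-chlorophenyl)ethyl group on the carbonyl carbon, or a methyl group on the urea nitrogen of compound 4, would speak to that, and the effect of fluoro on the aromatic carbon remains open for the urea.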